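Trading trifluoromethyl for chloro on compound 3

The compounds below may be only part of what the source reports. "The series", "measured", "known", "first", "only" and "open" are said of these compounds alone.

In a functional assay on MCF7 cells (Homo sapiens) for inhibition, read by MTT assay, with a stated time of 72 h (on this read-out lower numbers stand for stronger inhibition and higher numbers for weaker inhibition), compound 1 `COc1cc(NC(C)CCCNC(=O)Nc2cccc(F)c2)c2ncccc2c1` gives 18000 nM as its reading, and compound 2 `COc1cc(NC(C)CCCNC(=O)Nc2cccc(C(F)(F)F)c2)c2ncccc2c1` gives 3300 nM as its reading. Compound 3 `COc1cc(NC(C)CCCNC(=O)NNC(=O)Nc2cccc(C(F)(F)F)c2)c2ncccc2c1` gives 190 nM as the lowest of the three numbers, and its gaps to both others lie beyond the scatter.

Compound 4 `COc1cc(NC(C)CCCNC(=O)NNC(=O)Nc2cccc(Cl)c2)c2ncccc2c1` has not been measured yet. It differs from compound 3 in one group only: chloro in place of trifluoromethyl on an aromatic carbon in other words, chloro in place of trifluoromethyl on an aromatic carbon.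

Within the data shown here, only one measured step touches this group, namely a 5.5-fold lower number from compound 1 to compound 2 (0.74 log units; beyond the scatter) with trifluoromethyl in place of fluoro. It is a modest step beyond the scatter. Among the measured compounds shown here, it offers only indirect guidance, since no measured compound carries chloro and compound 1 and compound 2 also differ from compound 3 in their chain. Still, in that single case the compound with trifluoromethyl had the lower number, so losing this group here points towards a higher number.

The estimated step is a 1.8-fold higher number from compound 3 to compound 4 (0.25 log units; within the scatter) and it is expected to be smaller than the measured one. Compound 4 is therefore expected near 340 nM with an estimated range from 120 nM to 900 nM in this assay once it is measured.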

Compound 4, half-maximal inhibitory concentration: 220 nM
Beside the measured number, compound 4's estimate is 1.5-fold (0.19 log units) above it; low and high end bracket the measured number.
By their numbers in this assay, from the lowest: compounds 3 and 4 (each within the scatter of the next); then compound 2; then compound 1.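

In this assay, the change from trifluoromethyl to chloro on this aromatic carbon gives a 1.2-fold higher number from compound 3 to compound 4 (0.06 log units; within the scatter) and so leaves the reading unchanged within the scatter, even though 4 heavy atoms give way to 1. Among these compounds, the only earlier step at this place, from fluoro to trifluoromethyl, lay beyond the scatter, but it was measured on compounds without the ((3-chlorophenyl)carbamoyl)amino unit, so a substituent change here does not always move the number. The larger differences appear when compound 4 is set against the compounds with the shorter chain, with a 15-fold lower number from compound 2 to compound 4 (1.18 log units; beyond the scatter) and an 82-fold lower number from compound 1 to compound 4 (1.91 log units; beyond the scatter) in this assay, although each of those steps changes both the chain and the ring substituent, and nothing measured here explains these readings.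

Open still is whether another group on the same aromatic carbon, such as a nitrile, a methyl or an amine, would also stay close to compound 3 and compound 4. Also open, going by these compounds, is how much of the large gaps belongs to the chain alone, which a chloro compound with the shorter chain would help to separate from the effect of the ring substituent.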